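Aryl ether series: chlorophenyl analogue of compound 2

The source may report more compounds than this note shows. Statements on the series, on what has been measured and on what is new or still open speak of the compounds shown alone.

Measured so far:
compound 1 `Cc1nn(-c2ncnc3nc[nH]c23)c2c1C(OCc1ccc(Cl)cc1Cl)CC(=O)N2` — 4 nM
compound 2 `Cc1nn(-c2ncnc3nc[nH]c23)c2c1C(OCCn1nccc1C)CC(=O)N2` — 10 nM

In a functional assay on HEK293 cells for agonist activity at G-protein coupled receptor 39 (Homo sapiens), read by scintillation proximity assay and inositol phosphate accumulation, with a stated time of 75 min, in the presence of a further agent that is not named here (a lower number here means that less compound is needed, a higher number that more compound is needed for the effect), compound 1 gives 4 nM and compound 2 gives 10 nM. Within the data shown here, compound 2 holds the higher of the two numbers; the single measured step, a 2.5-fold higher number from compound 1 to compound 2 (0.40 log units; beyond the scatter), separates it from compound 1.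

Compound 3 `Cc1nn(-c2ncnc3nc[nH]c23)c2c1C(OCc1ccccc1Cl)CC(=O)N2` is not yet measured. It differs from compound 2 by 2-chlorophenyl in place of (5-methyl-1H-pyrazol-1-yl)methyl on a saturated chain carbon bound to an oxygen on a saturated carbon. Among the measured compounds shown here, the only step that bears on this is a 2.5-fold higher number from compound 1 to compound 2 (0.40 log units; beyond the scatter), where a chlorine-bearing phenyl ether stood at the lower number; compound 3 carries one chlorine on the phenyl where compound 1 carries two, so a return toward the number of compound 1 is expected, though not necessarily the whole way. The step expected is a 1.7-fold lower number from compound 2 to compound 3 (0.22 log units; within the scatter), a decrease of modest size. Compound 3 is estimated at 6 nM in this assay, with a range from 2.5 nM to 15 nM.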

Compound 3, half-maximal effective concentration: 2 nM
Beside the measured number, compound 3's estimate is 3.0-fold (0.48 log units) above it, outside the stated range (below it).
By their numbers in this assay, from the lowest: compounds 3 and 1 (each within the scatter of the next); then compound 2.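

In this assay, the lower number of the chlorophenyl ethers over the pyrazole ether does not depend on the second chlorine: with a single chlorine the change still gives a 5.0-fold lower number from compound 2 to compound 3 (0.70 log units; beyond the scatter). Removing that chlorine gives a 2.0-fold lower number from compound 1 to compound 3 (0.30 log units; within the scatter), so hydrogen in place of chloro on an aromatic carbon cannot be told apart from no change here, and the phenyl ethers sit together, with the (5-methyl-1H-pyrazol-1-yl)methyl ether apart from both. No measurement accounts for either step.

The compounds shown leave open whether the remaining chlorine contributes at all, a question for the plain phenyl ether or for fluoro, methoxy or a carboxylic acid in its place. Also open, on these data alone, is how a longer chain between the oxygen and the phenyl ring would read.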